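The source may report more compounds than this note shows. Statements on the series, on what has been measured and on what is new or still open speak of the compounds shown alone.

Measured compounds:
- compound 1 `COc1ccc(C(=O)N2C[C@H](Oc3nccc(C#N)c3C)CC[C@H]2C)c(-n2nccn2)n1`: 3570 nM
- compound 2 `Cc1c(C#N)ccnc1O[C@@H]1CC[C@@H](C)N(C(=O)c2ccccc2C(F)(F)F)C1`: 1160 nM
- compound 3 `CC(=O)Nc1cc(C(=O)N2C[C@H](Oc3nccc(C#N)c3C)CC[C@H]2C)c(-c2ccccc2)cn1`: 10 nM

The three compounds were compared in an assay on cells for displacement of a labelled ligand from Orexin/Hypocretin receptor type 1 (Homo sapiens); on this read-out higher numbers stand for weaker inhibition and lower numbers for stronger inhibition. Compound 2 stands second highest of the three numbers; its nearest neighbour is compound 1, which gives 3570 nM, a gap beyond the scatter, while compound 3, with 10 nM, lies far lower and is the strongest inhibitor of the set. No two of these compounds differ in a single place, so no measured single-point step is available to anchor what follows.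

Compound 4 `CCOc1ccccc1C(=O)N1C[C@H](Oc2nccc(C#N)c2C)CC[C@H]1C` has not yet been measured. It differs from compound 2 by ethoxy in place of trifluoromethyl on an aromatic carbon. With no measured step of this kind in the set, the direction of the change is open. The other compound carrying an alkoxy group on its aromatic ring is compound 1, which gives 3570 nM, but it also differs from compound 2 in further places, so it offers no clean guide.

The authors therefore expect for compound 4 a step from compound 2 that stays within the scatter, a 1.3-fold higher number from compound 2 to compound 4 (0.11 log units; within the scatter). They estimate for compound 4 a value of 1500 nM in this assay, with a range from 400 nM to 6000 nM.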

Compound 4, inhibition constant: 594 nM
Beside the measured number, compound 4's estimate is 2.5-fold (0.40 log units) above it; the measured number falls inside the stated range.
By their numbers in this assay, from the lowest: compound 3; then compounds 4 and 2 (each within the scatter of the next); then compound 1.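

In this assay, within the data shown here, putting ethoxy in place of trifluoromethyl on an aromatic carbon ortho to a large group gives a 2.0-fold lower number from compound 2 to compound 4 (0.29 log units; within the scatter), the only single-place step in the set so far. At this position, then, the read-out does not separate the two groups, although trifluoromethyl brings 4 heavy atoms and no hydrogen-bond acceptor, and ethoxy brings 3 heavy atoms and 1 hydrogen-bond acceptor. No measured information here bears on why these two groups give values so close together.

As far as these compounds go, whether an amine, a carboxylic acid or a longer chain such as propoxy in this place would take the number beyond the scatter remains open, as does whether ethoxy and trifluoromethyl would also match on the more heavily substituted aromatic rings of compound 1 and compound 3. No single-place step links either of those two compounds to compound 2 or compound 4, so the features behind their values cannot be read from the compounds shown.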